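The source may hold more compounds than are shown below. What is called first, only, known or untested is meant among the compounds shown, and "the series" means these compounds.

Working notes on the series. The shared core is that of compound 1 `COc1ccc(/C=C/C(=O)Nc2nc(-c3c(C)cc(C)cc3C)cs2)cc1`; in a functional assay on K562 cells (Homo sapiens) for inhibition, read by MTT assay, with a stated time of 96 h (on this read-out higher numbers stand for weaker inhibition and lower numbers for stronger inhibition), compound 1 gives 4160 nM. Compound 2 `COCCOc1ccc(/C=C/C(=O)Nc2nc(-c3c(C)cc(C)cc3C)cs2)cc1` carries a 2-methoxyethoxy on the aromatic carbon, and in this assay compound 2 gives 1490 nM, the lowest of the three numbers measured; the step is a 2.8-fold lower number from compound 1 to compound 2 (0.45 log units; beyond the scatter). Compound 3 `Cc1cc(C)c(-c2csc(NC(=O)/C=C/c3ccc(F)cc3)n2)c(C)c1`, with fluoro on that aromatic carbon, gives in this assay compound 3 14000 nM, so that a 3.4-fold higher number from compound 1 to compound 3 (0.53 log units; beyond the scatter) and a 9.4-fold higher number from compound 2 to compound 3 (0.97 log units; beyond the scatter).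

Compound 4 `Cc1cc(C)c(-c2csc(NC(=O)/C=C/c3ccc([N+](=O)[O-])cc3)n2)c(C)c1` is not yet measured. Relative to compound 2, nitro in place of 2-methoxyethoxy on an aromatic carbon: the 2-methoxyethoxy leaves and a nitro enters on the aromatic carbon. The measured steps that bear on this are the two in which an alkoxy group on that aromatic carbon was exchanged for another substituent, a 3.4-fold higher number from compound 1 to compound 3 (0.53 log units; beyond the scatter) and a 9.4-fold higher number from compound 2 to compound 3 (0.97 log units; beyond the scatter), both beyond the scatter and both toward weaker inhibition. Among the measured compounds shown here, no measured compound carries a nitro, and the data give no direct comparison of nitro against fluoro, so the size is uncertain. Still, giving up the 2-methoxyethoxy of compound 2 is expected to cost, and a higher number is expected in this assay, a 5.4-fold higher number from compound 2 to compound 4 (0.73 log units; beyond the scatter). Compound 4 is therefore estimated at 8000 nM in this assay, with a range of 2500 nM to 25000 nM.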

Compound 4, half-maximal inhibitory concentration: 32200 nM
The estimate for compound 4 lay 4.0-fold (0.60 log units) below the measured number; the whole stated range lies below it.
By their numbers in this assay, from the lowest: compound 2; then compound 1; then compound 3; then compound 4.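

Among the compounds shown here, on the aromatic carbon para to a large group, nitro gives the highest number of the four in this assay, with a 22-fold higher number from compound 2 to compound 4 (1.33 log units; beyond the scatter) as the largest step so far and a 7.7-fold higher number from compound 1 to compound 4 (0.89 log units; beyond the scatter) as the step from the smaller alkoxy group. The series also now has its first comparison between two groups that are not alkoxy, and a 2.3-fold higher number from compound 3 to compound 4 (0.36 log units; beyond the scatter) shows that the outcome at this position is not fixed merely by losing the alkoxy group, since nitro and fluoro stand apart beyond the scatter. Among these four compounds, both alkoxy compounds, 2-methoxyethoxy in compound 2 and methoxy in compound 1, give lower numbers than fluoro in compound 3 and nitro in compound 4, with no compound against this split, but nothing available here explains the order.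

Open, going by these compounds, is where an amine, a hydroxyl or a carboxylic acid on this carbon would fall in this order, and whether a longer ether chain than 2-methoxyethoxy would lower the number further. Also open, on these data alone, is whether the same order would hold with a different group in place of the trimethylphenyl substituent of the shared core.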